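Methyl to fluoro on the sulfonyl aryl ring

The source may report more compounds than this note shows. Statements on the series, on what has been measured and on what is new or still open speak of the compounds shown alone.

Measured compounds:
compound 1 `Cc1ccc(S(=O)(=O)c2cnc3cc(Cl)ccc3c2N2CCC(C)CC2)cc1F`: 85%
compound 2 `Cc1ccc(S(=O)(=O)c2cnc3ccc(Cl)cc3c2N2CCC(C)CC2)cc1F`: 68%
compound 3 `COc1ccc(S(=O)(=O)c2cnc3cc(F)ccc3c2N2CCC(C)CC2)cc1OC`: 83%

In an assay on isolated protein for displacement of a labelled ligand from metabotropic glutamate receptor 5 (Homo sapiens), with a stated time of 60 min, tested at 1 uM (a higher number here means more inhibition at the concentration tested (going by the name of the read-out), a lower number less inhibition), compound 1 gives the highest of the three numbers. Compound 3 sits within the scatter of compound 1, so no order can be read between the two. Compound 2 lies beyond the scatter below compound 1, the only gap among the three that counts as a difference. Among the compounds with values here, no two of the measured compounds differ in a single place, so no step on a single change is available from the data itself.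

Compound 4 `CC1CCN(c2c(S(=O)(=O)c3ccc(F)c(F)c3)cnc3cc(Cl)ccc23)CC1` is not yet measured. Against compound 1 the change is fluoro in place of methyl on an aromatic carbon. Nothing measured here speaks to a methyl against a fluoro at this position, so the expectation rests on compound 1 alone. The step is expected to be small: a number 9 percentage points lower from compound 1 to compound 4 (within the scatter), a slight decrease or none beyond the scatter. For compound 4 the estimate in this assay is 76%, with a range from 55% to 90%.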

Compound 4, a percentage reported as inhibition, at one concentration (the size of the read-out at that concentration, not a potency): 90%
For compound 4 the middle estimate is 14 percentage points below the measured one; the measured number falls inside the stated range.
By their numbers in this assay, from the lowest: compound 2; then compounds 3, 1 and 4 (each within the scatter of the next).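

In this assay, within the data shown here, fluoro in place of methyl on this aromatic carbon, para to a large group, gives a number 5 percentage points higher from compound 1 to compound 4 (within the scatter) and is the first single-place comparison. The 3-fluoro-4-methylphenyl and 3,4-difluorophenyl groups therefore cannot be told apart in this read-out, and the methyl is not required to keep the inhibition seen with compound 1. No measured information bears on the reason for this result.

Still open, from the compounds shown here alone, is how this carbon responds to groups of other kinds, such as an amine, a carboxylic acid or a longer chain like propyl. Going by these compounds, the read-out is taken at one concentration and is not a potency, so whether compound 1 and compound 4 would separate across a full concentration series also remains open.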